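The compounds below may be only part of what the source reports. "The series", "measured", "known", "first", "only" and "open" are said of these compounds alone.

Notes on the quinoline sulfone series.

Three compounds have numbers in an ADME assay on microsomes from liver (Homo sapiens) for metabolic stability, tested at 2.5 uM; a lower number here means slower removal, a higher number faster removal of the compound. Compound 1 `COc1cccc(S(=O)(=O)c2cnc3cc(F)ccc3c2-c2cccc(Cl)c2)c1` gives 2.97 mL/min. Compound 2 `COc1cccc(S(=O)(=O)c2cnc3cc(F)ccc3c2-c2cccc(F)c2)c1` gives 3.36 mL/min. Compound 3 `COc1cccc(-c2c(S(=O)(=O)c3ccc(C)c(C)c3)cnc3cc(F)ccc23)c1` gives 8.78 mL/min. Going by the values given here, the one step measured between neighbours, a 1.1-fold higher number from compound 1 to compound 2 (0.05 log units; within the scatter), covers fluoro in place of chloro on an aromatic carbon and lies within the scatter. Among the compounds with values here, compound 2 thus stands close to compound 1 in this assay, while compound 3 gives a higher number than either; no single-point step links compound 3 to compound 2, so only the two values themselves can be compared.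

Compound 4 `O=S(=O)(c1cc(Cl)cc(Cl)c1)c1cnc2cc(F)ccc2c1-c1cccc(F)c1` differs from compound 2 by 3,5-dichlorophenyl in place of 3-methoxyphenyl on a sulfonyl sulfur. Within the data shown here, no measured step in this assay alters the aryl group on the sulfonyl sulfur, so no step directly bears on this change. Among the measured compounds shown here, the only substituent step seen, from compound 1 to compound 2, was within the scatter, and compound 3, with a different aryl on the sulfonyl sulfur, gives a number roughly in the range of the higher values here. On that basis compound 4 is expected to give 4 mL/min, with a range of 2 mL/min to 8.5 mL/min, which as a step means a 1.2-fold higher number from compound 2 to compound 4 (0.08 log units; within the scatter) and is expected to stay near the scatter of the measurement.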

Compound 4, intrinsic clearance in a liver preparation (reported as CLH), per the amount of preparation that the assay uses: 0.41 mL/min
Estimate against measurement, compound 4: 9.8-fold (0.99 log units) above, outside the stated range (below it).
By their numbers in this assay, from the lowest: compound 4; then compounds 1 and 2 (each within the scatter of the next); then compound 3.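

In this assay, the aryl group on the sulfonyl sulfur proves able to shift the number: 3,5-dichlorophenyl in place of 3-methoxyphenyl gives an 8.2-fold lower number from compound 2 to compound 4 (0.91 log units; beyond the scatter). The only earlier step, a 1.1-fold higher number from compound 1 to compound 2 (0.05 log units; within the scatter), changed a different place and stayed within the scatter, so this is the first single change in the series shown to move the read-out beyond it. Nothing at hand accounts for the size of this step.

The compounds shown do not separate the loss of the methoxy group from the entry of the two chlorine atoms, nor show whether the step holds with the chloro-bearing partner of compound 1. As far as these compounds go, how an amine or a carboxylic acid on this aryl group would read also remains open.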